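The source may report more compounds than this note shows. Statements on the series, on what has been measured and on what is new or still open speak of the compounds shown alone.

Working notes on the series.

Compound 1 `CCOc1cc(CNc2nc3c(N)ncnc3n2[C@@H]2O[C@H](CO)[C@@H](O)[C@H]2O)ccc1-c1ccccc1` gives 2300 nM in an assay on COS-7 cells for inhibition of sodium/nucleoside cotransporter 2 (Homo sapiens), read by scintillation counting (on this read-out higher numbers stand for weaker inhibition and lower numbers for stronger inhibition), the lowest of the three numbers recorded so far. Compound 2 `COC(=O)COc1cc(CNc2nc3c(N)ncnc3n2[C@@H]2O[C@H](CO)[C@@H](O)[C@H]2O)ccc1-c1ccccc1` gives 3300 nM and compound 3 `NC(=O)COc1cc(CNc2nc3c(N)ncnc3n2[C@@H]2O[C@H](CO)[C@@H](O)[C@H]2O)ccc1-c1ccccc1` gives 5500 nM. The step of a 1.4-fold higher number from compound 1 to compound 2 (0.16 log units; within the scatter) stays within the scatter, while the step of a 2.4-fold higher number from compound 1 to compound 3 (0.38 log units; beyond the scatter) is a modest shift beyond it, so compound 1 sits at the lower edge without being clearly separated from compound 2. Between the two altered chains the step of a 1.7-fold higher number from compound 2 to compound 3 (0.22 log units; within the scatter) is within the scatter.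

Compound 4 `Nc1ncnc2c1nc(NCc1ccc(-c3ccccc3)c(OCCCCCO)c1)n2[C@@H]1O[C@H](CO)[C@@H](O)[C@H]1O` is the next member, not yet measured. It differs from compound 1 by 3-hydroxypropyl in place of hydrogen on a saturated chain carbon, two bonds along the chain from an oxygen on an aromatic ring. The two measured steps that bear on this change are those from compound 1 to compound 2 and from compound 1 to compound 3, since both alter the same saturated chain carbon bound to the ring oxygen; one was within the scatter, the other a modest rise. A change at the same chain end that is larger in atom count is therefore expected to move the number upward by a small amount, around the size of the step of a 1.5-fold higher number from compound 1 to compound 4 (0.18 log units; within the scatter), with no firm basis for a shift beyond that. Compound 4 is estimated at 3500 nM, with a range from 1500 nM to 8000 nM.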

Compound 4, half-maximal inhibitory concentration: 1600 nM
Compound 4: middle estimate off by 2.2-fold (0.34 log units), on the high side; low and high end bracket the measured number.
By their numbers in this assay, from the lowest: compounds 4, 1, 2 and 3 (each within the scatter of the next, the first and the last beyond it).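

In this assay, the 3-hydroxypropyl group on the saturated chain carbon, two bonds along the chain from an oxygen on an aromatic ring, leaves the read-out within the scatter: the step of a 1.4-fold lower number from compound 1 to compound 4 (0.16 log units; within the scatter) does not separate the (5-hydroxypentyl)oxy chain from the ethoxy group, so this position accepts a much larger chain without a measurable loss. The new chain does separate from both carbonyl-bearing chains, with a 2.1-fold lower number from compound 2 to compound 4 (0.31 log units; beyond the scatter) and a 3.4-fold lower number from compound 3 to compound 4 (0.54 log units; beyond the scatter) both beyond the scatter, whereas compound 1 stood clear only of compound 3 and not of compound 2. Nothing measured in the series accounts for these steps.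

Compound 4 changes chain length and adds a hydroxyl in the same step, so the compounds shown do not say which of the two matters, and a plain pentyloxy chain would be needed to pull them apart. Also open, going by these compounds, is how this position responds to a chain ending in an amine or a carboxylic acid, or to a longer chain than the (5-hydroxypentyl)oxy group.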